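Nitro for hydroxy on the shared core: cytotoxicity notes

A few compounds are considered here, and "the series" means these few. Any claim that something is new, unique, unknown or untested is made for them only; others in the source may bear on it.

Measured so far in an ADME assay on BHK cells (Mesocricetus auratus) for cytotoxicity, read by MTT assay, with a stated time of 96 h; on this read-out higher numbers stand for lower toxicity in this test and lower numbers for higher toxicity in this test:
Compound 1 `Oc1ccc(-c2nc3cc(C(F)(F)F)ccc3[nH]2)cc1` gives > 100000 nM, which is a limit of the assay and not a number.
Compound 2 `Cn1c(-c2ccc(NC(=O)CN3CCCC3)cc2)nc2cc(C(F)(F)F)ccc21` gives 27000 nM.
Compound 3 `Nc1ccc(-c2nc3cc(Cl)c(Cl)cc3[nH]2)cc1` gives 30000 nM.

Within the data shown here, compound 1 stands at the limit of > 100000 nM in this assay, at which 1 of the 3 values shown sits, so only a bound is known for it, and no step between measured compounds exists in this set. Compound 4 `O=[N+]([O-])c1ccc(-c2nc3cc(C(F)(F)F)ccc3[nH]2)cc1` differs from compound 1 in nitro in place of hydroxy on an aromatic carbon. Without a measured step to lean on, the step of an at least 1.6-fold lower number from compound 1 to compound 4 (0.22 log units; that floor lies within the scatter) is expected to run toward higher toxicity, modestly beyond the scatter, though a renewed limit would not be surprising. For compound 4 a half-maximal cytotoxic concentration of 60000 nM is estimated, with a range from 15000 nM to 150000 nM.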

Compound 4, half-maximal cytotoxic concentration: 18000 nM
Compound 4: middle estimate off by 3.3-fold (0.52 log units), on the high side; measured number inside the range.
By their numbers in this assay, from the lowest: compounds 4, 2 and 3 (each within the scatter of the next). At a limit, above all of these: compound 1.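

Nitro in place of hydroxy on an aromatic carbon, para to a large group, gives in this assay an at least 5.5-fold lower number from compound 1 to compound 4 (0.74 log units; beyond the scatter), so this position does affect the read-out, and the change runs toward higher toxicity in this test. The true size of the step stays unknown, because compound 1 sits at a limit, and the step is only a floor: the limit of > 100000 nM in this assay, at which 1 of the 4 values shown sits.

Going by these compounds, whether the loss of hydroxy or the entry of nitro drives the step stays open. So does what a methoxy group or a nitrile would do at this position.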